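A few compounds are considered here, and "the series" means these few. Any claim that something is new, unique, unknown or untested is made for them only; others in the source may bear on it.

Measured compounds:
- compound 1, `Cc1noc(NS(=O)(=O)c2cccc3ccccc23)c1C`: 20000 nM
- compound 2, `CNc1cccc2c(S(=O)(=O)Nc3onc(C)c3C)cccc12`: 130 nM
- compound 3, `Cc1noc(NS(=O)(=O)c2cccc3c(N4CCCC4=O)cccc23)c1C`: 130 nM

In an assay on VSM-A10 cells for antagonist activity at Endothelin-1 receptor (Rattus norvegicus) (on this read-out lower numbers stand for stronger inhibition and higher numbers for weaker inhibition), compound 3 stands level with compound 2 at the digits shown, and the two together give the lowest numbers of the three; compound 1 sits far apart, with a 150-fold lower number from compound 1 to compound 3 (2.19 log units; beyond the scatter). Compound 4, `Cc1noc(NS(=O)(=O)c2cccc3c(N/C(S)=N/c4ccccc4)cccc23)c1C`, is the next step from compound 3: a group of 10 heavy atoms (7 carbon, 2 nitrogen, 1 sulfur; one six-membered aromatic ring of carbon only) in place of a group of 6 heavy atoms (4 carbon, 1 nitrogen, 1 oxygen; one five-membered non-aromatic ring with 1 hetero atom), on an aromatic carbon.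

Two earlier steps bear on this change. Adding a group at this same aromatic carbon gave a 150-fold lower number from compound 1 to compound 2 (2.19 log units; beyond the scatter) and a 150-fold lower number from compound 1 to compound 3 (2.19 log units; beyond the scatter), so an occupied position here went with much lower numbers in both cases. Swapping one such group for another gave no change at the digits printed from compound 2 to compound 3 (within the scatter). Compound 4 keeps the position occupied, with a nitrogen attached to the ring as in compounds 2 and 3, but the entering group is larger than either. On that basis, compound 4 is expected to show at most a modest step, a 1.3-fold lower number from compound 3 to compound 4 (0.11 log units; within the scatter), with no clear direction beyond the scatter. The estimate for compound 4 in this assay is 100 nM, with a range from 20 nM to 500 nM.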

Compound 4, half-maximal inhibitory concentration: 150 nM
For compound 4 the middle estimate is 1.5-fold (0.18 log units) below the measured one, within the range that was stated.
By their numbers in this assay, from the lowest: compounds 2, 3 and 4 (each within the scatter of the next); then compound 1.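

In this assay, the position proved to accept a much larger group than the earlier compounds had shown: the entering group, with its six-membered aromatic ring of carbon only, gave a 1.2-fold higher number from compound 3 to compound 4 (0.06 log units; within the scatter) and a 1.2-fold higher number from compound 2 to compound 4 (0.06 log units; within the scatter) on the same scale. Set against the hydrogen of the first compound, it gave a 130-fold lower number from compound 1 to compound 4 (2.12 log units; beyond the scatter) in a step of the same order as those seen for methylamino and 2-oxopyrrolidin-1-yl, so the gain from occupying this carbon held across all three groups, with none of the three going against it. As far as these compounds go, whether an amine without a carbon substituent, a carboxylic acid or a longer chain at this aromatic carbon would stay level with these three remains open. Nothing shown here gives a reason why such different groups read alike.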